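Ethylphenyl Replaces the Halogenated Aniline on the Core

A few compounds are considered here, and "the series" means these few. Any claim that something is new, unique, unknown or untested is made for them only; others in the source may bear on it.

Compound 2 `NS(=O)(=O)c1ccc(NC(=S)Nc2ccc3ncnc(Nc4cccc(Cl)c4F)c3c2)cc1` carries a 3-chloro-2-fluorophenyl group on a nitrogen on an aromatic ring of the shared core. In a functional assay on A549 cells (Homo sapiens) for antiproliferative activity, read by MTT assay, with a stated time of 72 h (on this read-out higher numbers stand for weaker inhibition and lower numbers for stronger inhibition), compound 2 gives > 40000 nM, which is a limit of the assay rather than a number. Its neighbour compound 1 `NS(=O)(=O)c1ccc(NC(=S)Nc2ccc3ncnc(Nc4ccc(F)c(Cl)c4)c3c2)cc1` bears a 3-chloro-4-fluorophenyl group at the same nitrogen. In this assay compound 1 gives > 40000 nM, again a limit. The step that the two limits leave unreadable from compound 1 to compound 2 therefore cannot be read, as both compounds rest at the limit of > 40000 nM in this assay, at which 2 of the 2 values shown sit.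

Compound 3 `CCc1ccc(Nc2ncnc3ccc(NC(=S)Nc4ccc(S(N)(=O)=O)cc4)cc23)cc1` arises from compound 2 through (4-ethylphenyl in place of 3-chloro-2-fluorophenyl on a nitrogen on an aromatic ring). Within the data shown here, no measured step bears directly on this exchange: the only recorded step, from compound 1 to compound 2, concerns a different change and is itself unreadable. Compound 3 is therefore expected to sit near the same limit, with a number no higher from compound 2 to compound 3 (the limit leaves the size open) carrying no direction beyond the scatter. The estimate for compound 3 in this assay is 40000 nM, with a range from 10000 nM to 100000 nM.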

Compound 3, half-maximal inhibitory concentration: 24600 nM
Compound 3: middle estimate off by 1.6-fold (0.21 log units), on the high side; measured number inside the range.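

Among these compounds, compound 3 is the only one of the three compounds whose result in this assay is a number rather than a limit, which shows that a 4-ethylphenyl group, carrying only carbon, can stand on this nitrogen of the shared core and bring the reading inside the range of the assay. Replacing the halogenated groups gives an at least 1.6-fold lower number from compound 2 to compound 3 (0.21 log units; that floor lies within the scatter), and it likewise gives an at least 1.6-fold lower number from compound 1 to compound 3 (0.21 log units; that floor lies within the scatter). Both steps are therefore floors and not sizes, and neither establishes a real gain on its own, because the true values of the two halogenated compounds remain hidden at the assay's limit: the limit of > 40000 nM in this assay, at which 2 of the 3 values shown sit.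

The step between the two halogenated groups still cannot be read, so the compounds shown do not tell whether moving the fluorine matters at all. They also leave open how the number would respond to a longer chain such as propyl in place of the ethyl group, or to an amine or a carboxylic acid on the same phenyl ring.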